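A few compounds are considered here, and "the series" means these few. Any claim that something is new, unique, unknown or untested is made for them only; others in the source may bear on it.

Working notes on the series in a functional assay on HL-60 cells (Homo sapiens) for antiproliferative activity, read by MTT assay, with a stated time of 72 h; on this read-out lower numbers stand for stronger inhibition and higher numbers for weaker inhibition:

- compound 1 `COc1ccc(OCCCON2C(N)=NC(N)=NC23CCOCC3)cc1`: 1670 nM
- compound 2 `NC1=NC2(CCOCC2)N(OCCCOc2ccccc2Cl)C(N)=N1`: 660 nM

Going by the values given here, compound 2, at 660 nM, holds the lower of the two numbers so far, and compound 1 is its only neighbour. Next is compound 3 `NC1=NC2(CCOCC2)N(OCCCOc2ccc(F)cc2)C(N)=N1`, with the change 4-fluorophenyl in place of 2-chlorophenyl on an oxygen on a saturated carbon.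

Among the compounds with values here, only one measured step bears on this place: a 2.5-fold lower number from compound 1 to compound 2 (0.40 log units; beyond the scatter), a modest one, going from 4-methoxyphenyl to 2-chlorophenyl. Within the data shown here, no compound with 4-fluorophenyl has a number yet, so this single step sets the likely size. A modest move back towards compound 1 in this assay is expected, though a result within the scatter would not surprise. The expected change is a 1.5-fold higher number from compound 2 to compound 3 (0.18 log units; within the scatter). For compound 3 the estimated value is 1000 nM, with an expected range of 400 nM to 2500 nM.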

Compound 3, half-maximal inhibitory concentration: 2380 nM
Compound 3: the middle estimate sits 2.4-fold (0.38 log units) below what was measured; the range from low to high includes it.
By their numbers in this assay, from the lowest: compound 2; then compounds 1 and 3 (each within the scatter of the next).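

In this assay, the advantage of compound 2 now holds against a second aryl group, since a 3.6-fold higher number from compound 2 to compound 3 (0.56 log units; beyond the scatter). The other new step, a 1.4-fold higher number from compound 1 to compound 3 (0.15 log units; within the scatter), lies within the scatter, so 4-fluorophenyl and 4-methoxyphenyl do not separate here, and among these three compounds only 2-chlorophenyl stands apart. Nothing available accounts for this difference.

As far as these compounds go, compound 2 differs from compound 3 in both the halogen and its place on the ring, so it remains open whether the chlorine or its place carries the difference. Also open, from the compounds shown here alone, is how a nitrile, an amine or a longer chain would behave at this position.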